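The source may hold more compounds than are shown below. What is called first, only, known or untested is meant among the compounds shown, and "the series" means these compounds.

Measured so far in a functional assay on LS180 cells (Homo sapiens) for cytotoxicity, read by MTT assay, with a stated time of 48 h; on this read-out higher numbers stand for weaker inhibition and lower numbers for stronger inhibition:
- compound 1 `CCCCCCCC(=O)NCC(=O)N[C@@H](C)C(=O)N[C@@H](CC(C)C)C(=O)NC(C)(C)C(=O)N[C@@H](CO)C(=O)N[C@H](C(=O)N[C@H](CO)CC(C)C)[C@@H](C)CC`: > 30000 nM
- compound 2 `CCCCCCCC(=O)NCC(=O)N[C@@H](C)C(=O)N[C@@H](CC(C)C)C(=O)N[C@](C)(CC)C(=O)N[C@@H](CO)C(=O)N[C@H](C(=O)N[C@H](CO)CC(C)C)[C@@H](C)CC`: > 30000 nM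
- compound 3 `CCCCCCCC(=O)NCC(=O)N[C@@H](C)C(=O)N[C@@H](CC(C)C)C(=O)NC(C)(C)C(=O)N[C@@H](C)C(=O)N[C@H](C(=O)N[C@H](CO)CC(C)C)[C@@H](C)CC`: > 30000 nM

All readings so far stand at the limit of > 30000 nM in this assay, at which 3 of the 3 values shown sit. Compound 3 gives > 30000 nM, which is a limit and not a number.

Compound 4 `CCCCCCCC(=O)NCC(=O)N[C@@H](C)C(=O)N[C@@H](CC(C)C)C(=O)N[C@](C)(CC)C(=O)N[C@@H](C)C(=O)N[C@H](C(=O)N[C@H](CO)CC(C)C)[C@@H](C)CC` differs from compound 3 by methyl in place of hydrogen on a saturated chain carbon, two bonds along the chain from an amide-type nitrogen and a carbonyl carbon. The same exchange occurs in a step that the two limits leave unreadable from compound 1 to compound 2. The other change carried by compound 4 occurs in a step that the two limits leave unreadable from compound 1 to compound 3. Neither gives a size to carry over, so no step beyond the scatter is expected in this assay, and another limit is the likely report. The expected step is a step that the limit leaves unreadable from compound 3 to compound 4. For compound 4 the estimate is 35000 nM, with an expected range of 15000 nM to 80000 nM.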

Compound 4, half-maximal inhibitory concentration: 7000 nM
Compound 4: the middle estimate sits 5.0-fold (0.70 log units) above what was measured, and the stated range ends above it.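

In this assay, methyl in place of hydrogen on a saturated chain carbon gives an at least 4.2-fold lower number from compound 3 to compound 4 (0.63 log units; beyond the scatter), the first readable effect of this exchange. Hydrogen in place of hydroxy gives an at least 4.2-fold lower number from compound 2 to compound 4 (0.63 log units; beyond the scatter), so that change also registers with the methyl present. The matching steps from compound 1 cannot be read, so each change shows a readable effect only with the other in place: the limit of > 30000 nM in this assay, at which 3 of the 4 values shown sit.

As far as these compounds go, the full size of both steps stays open, since each starts from a limit. Also open, from the compounds shown here alone, is whether a longer chain in place of the entering methyl, or an amine in place of the hydroxy, would give a lower number.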